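A few compounds are considered here, and "the series" means these few. Any claim that something is new, unique, unknown or untested is made for them only; others in the source may bear on it.

Measured in a functional assay on OCI-Ly3 cells (Homo sapiens) for antiproliferative activity; on this read-out lower numbers stand for an effect already at smaller amounts and higher numbers for an effect only at larger amounts of compound:
- compound 1 `O=C(Nc1cnc(-n2nccn2)c(Cl)c1)Nc1cnc2ccccc2c1C1CCCC1`: 7020 nM
- compound 2 `O=C(Nc1cnc(-n2nccn2)c(Cl)c1)Nc1cnc2ccccc2c1C1CC1`: 1580 nM

Of these, compound 2 has the lower number in this assay, at 1580 nM. Compound 3 `O=C(Nc1cnc(-n2nccn2)c(Cl)c1)Nc1cnc2cc(Cl)ccc2c1C1CC1` differs from it by chloro in place of hydrogen on an aromatic carbon, with chloro in place of hydrogen on an aromatic carbon. Among the measured compounds shown here, the only measured step, a 4.4-fold lower number from compound 1 to compound 2 (0.65 log units; beyond the scatter), changed a different group, so it offers a rough guide to size but none to direction. A modest step towards a lower number is tentatively expected in this assay. The expected step is a 2.0-fold lower number from compound 2 to compound 3 (0.30 log units; within the scatter). Compound 3 is estimated at 800 nM, with an expected range of 180 nM to 3200 nM.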

Compound 3, half-maximal effective concentration: > 20000 nM
Compound 3: a limit, no number (the forecaster's own chance of this, stated with the estimate: 3%); at least 25-fold (1.39 log units) between middle value and limit.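

In this assay compound 3 gives > 20000 nM, which is a limit and not a number. Chloro in place of hydrogen on this aromatic carbon brings an at least 12-fold higher number from compound 2 to compound 3 (1.10 log units; beyond the scatter), so a change on this ring of the core, and not only on the cycloalkyl group, moves the read-out strongly, and here towards larger amounts. How large the step truly is stays unknown, as the value is bounded on one side only: the limit of > 20000 nM in this assay, at which 1 of the 3 values shown sits.

As far as these compounds go, whether fluoro, methoxy or an amine on this carbon would behave like chloro remains open. So does whether chloro on the other carbons of this ring would have the same outcome.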